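Anilinoquinazoline-derived acetamides: halogen swap on the pendant aniline

The source may hold more compounds than are shown below. What is called first, only, known or untested is meant among the compounds shown, and "the series" means these compounds.

Two compounds in this set have a number. In a functional assay on PC-3 cells (Homo sapiens) for inhibition, read by MTT assay, with a stated time of 72 h (on this read-out lower numbers stand for stronger inhibition and higher numbers for weaker inhibition), compound 2 `C=CC(=O)Nc1cccc(NC(=O)CSc2nc(Nc3ccccc3F)c3ccccc3n2)c1` gives 9340 nM, and compound 1 `O=C(CSc1nc(Nc2ccccc2)c2ccccc2n1)Nc1ccccc1Cl` gives 14600 nM; the two values lie within the usual scatter of each other, so neither can be set apart from the other. Compound 3 `C=CC(=O)Nc1cccc(NC(=O)CSc2nc(Nc3ccc(Br)cc3)c3ccccc3n2)c1` has not been measured. It differs from compound 2 by 4-bromophenyl in place of 2-fluorophenyl on a nitrogen on an aromatic ring. Going by the values given here, no measured pair shows this exact change, so only the common core anchors the expectation. The step from compound 2 to compound 3 is expected to be small, a 1.0-fold lower number from compound 2 to compound 3 (0.02 log units; within the scatter), not beyond the scatter in either direction. Compound 3 is therefore estimated at 9000 nM, with a range from 3000 nM to 27000 nM.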

Compound 3, half-maximal inhibitory concentration: 12400 nM
Estimate against measurement, compound 3: 1.4-fold (0.14 log units) below; low and high end bracket the measured number.
By their numbers in this assay, from the lowest: compounds 2, 3 and 1 (each within the scatter of the next).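

In this assay, going by these compounds alone, the change to 4-bromophenyl in place of 2-fluorophenyl gives a 1.3-fold higher number from compound 2 to compound 3 (0.12 log units; within the scatter) and is the first step measured on this nitrogen. For this pair, exchanging one halogen-bearing phenyl for another leaves the read-out within the scatter, so the two compounds cannot be set apart. Nothing measured here bears on the reason for this result. This single step cannot separate the identity of the halogen from its place on the ring. Going by these compounds, what an amine or a carboxylic acid on this phenyl ring would do remains open.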